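This account rests on a few compounds, and the source may have more. Where it says the series, first, only, none or still open, it means among the compounds named here.

Three compounds share one core and differ only in the group on its left end. In a functional assay on HCT-116 cells (Homo sapiens) for inhibition, read by luminescence and resazurin assay, with a stated time of 3 days (on this read-out higher numbers stand for weaker inhibition and lower numbers for stronger inhibition), compound 1 `CNc1nc(NCc2ccc(C(=O)NC3CCN(Cc4ccc(F)cc4)CC3)cc2)c2cc(C)ccc2n1` gives 1200 nM, compound 2 `Cc1ccc2nc(N3CCNC(C)C3)nc(NCc3ccc(C(=O)NC4CCN(Cc5ccc(F)cc5)CC4)cc3)c2c1` gives 2000 nM, and compound 3 `CCCNc1nc(NCc2ccc(C(=O)NC3CCN(Cc4ccc(F)cc4)CC3)cc2)c2cc(C)ccc2n1` gives 1600 nM. Compound 3 sits close to both of them, with a 1.3-fold lower number from compound 2 to compound 3 (0.10 log units; within the scatter) and a 1.3-fold higher number from compound 1 to compound 3 (0.12 log units; within the scatter), so all three numbers are within the usual scatter of one another. Compound 4 `CCCNc1nc(NCc2ccc(C(=O)NC3CCN(C(=O)c4ccc(F)cc4)CC3)cc2)c2cc(C)ccc2n1` is altered at the opposite end instead: (4-fluorophenyl)carbonyl in place of 4-fluorobenzyl on an amine nitrogen in a ring. For the measured compounds named here, none of the measured steps touches this part of the molecule, so they offer no direct guidance; they only show that the numbers have stayed close together so far. The number for compound 4 in this assay is therefore expected near 2500 nM, within 800 nM to 8000 nM. For compound 4 the expected step is a 1.6-fold higher number from compound 3 to compound 4 (0.19 log units; within the scatter), with wide uncertainty in either direction.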

Compound 4, half-maximal inhibitory concentration: 6800 nM
Beside the measured number, compound 4's estimate is 2.7-fold (0.43 log units) below it; measured number inside the range.
By their numbers in this assay, from the lowest: compounds 1, 3 and 2 (each within the scatter of the next); then compound 4.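

In this assay, putting (4-fluorophenyl)carbonyl in place of 4-fluorobenzyl on the amine nitrogen in the ring gives a 4.3-fold higher number from compound 3 to compound 4 (0.63 log units; beyond the scatter), a clear weakening of inhibition. For the compounds shown here, the earlier steps, all at a different place on the molecule, stayed within the scatter, so this is the first sign that the numbers respond to a change. Nothing available explains this loss. As far as these compounds go, it remains open whether other groups on this nitrogen, such as a methyl or a 4-fluorophenylsulfonyl, would weaken inhibition in the same way. From the compounds shown here alone, it is also open whether the same swap would have a similar effect with methylamino in place of propylamino.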